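Compound 1 to compound 4: a relocated aryl halogen

The compounds below may be only part of what the source reports. "The series", "measured", "known", "first", "only" and "open" are said of these compounds alone.

Compound 1 `COc1ccc(C(=O)/C=C/c2ccc(Br)cc2)c2c1C=CC(C)(C)O2` is the reference point of the series. In a functional assay on SK-OV-3 cells (Homo sapiens) for antiproliferative activity, read by MTT assay, with a stated time of 24 h (a higher number here means a weaker inhibitor, a lower number a stronger inhibitor), compound 1 gives > 10000 nM, which is a limit of the assay rather than a number. Compound 2 `COc1ccc(C(=O)/C=C/c2ccc(N3CCCC3)cc2)c2c1C=CC(C)(C)O2` gives 7370 nM in this assay, and compound 3 `COc1ccc(C(=O)/C=C/c2ccc(-n3ccnc3)cc2)c2c1C=CC(C)(C)O2` gives 7200 nM. The measured steps are small: an at least 1.3-fold lower number from compound 1 to compound 2 (0.13 log units; that floor lies within the scatter), an at least 1.3-fold lower number from compound 1 to compound 3 (0.14 log units; that floor lies within the scatter) and a 1.0-fold lower number from compound 2 to compound 3 (0.01 log units; within the scatter); compound 1 sits at the limit of > 10000 nM in this assay, at which 1 of the 3 values shown sits. Compound 4 `COc1ccc(C(=O)/C=C/c2cccc(Cl)c2)c2c1C=CC(C)(C)O2` differs from compound 1 by 3-chlorophenyl in place of 4-bromophenyl on a double-bonded chain carbon bound to a double-bonded chain carbon. Within the data shown here, no measured step exchanges one halogenated phenyl for another; the steps from compound 1 only replace bromo with nitrogen groups and stay within the scatter. Compound 4 is therefore expected to remain weak, with a step that the limit leaves unreadable from compound 1 to compound 4 as the estimated step. Compound 4 is estimated at 15000 nM, between 6000 nM and 40000 nM.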

Compound 4, half-maximal inhibitory concentration: > 10000 nM
Compound 4 ended at the assay's limit (the forecaster's own chance of this, stated with the estimate: 70%); the middle value does not contradict the limit.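

Among these compounds, compound 1 and compound 4 both stand at a limit of the assay, so no step between them can be read: the limit of > 10000 nM in this assay, at which 2 of the 4 values shown sit. On these data alone, how 3-chlorophenyl and 4-bromophenyl compare on the shared core remains open.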